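Series notes toward compound 4

The source may report more compounds than this note shows. Statements on the series, on what has been measured and on what is new or still open speak of the compounds shown alone.

compound 1 `COc1ncnc2c1c(I)cn2[C@@H]1O[C@H](CO)[C@@H](O)[C@H]1O` — > 20000 nM
compound 2 `COc1ncnc2c1c(-c1ccccc1)cn2[C@@H]1O[C@H](CO)[C@@H](O)[C@H]1O` — > 20000 nM
compound 3 `CNc1ncnc2c1c(-c1ccccc1)cn2[C@@H]1O[C@H](CO)[C@@H](O)[C@H]1O` — > 20000 nM

In a functional assay on CEM-DNR-bulk cells (Homo sapiens), read by MTT assay, with a stated time of 72 h (a lower number here means a stronger inhibitor, a higher number a weaker inhibitor), compound 1 gives only a limit, > 20000 nM. Compound 2 also gives only a limit in this assay, > 20000 nM. Compound 3 gives only a limit in this assay as well, > 20000 nM. The two measured steps, a step that the two limits leave unreadable from compound 1 to compound 2 and a step that the two limits leave unreadable from compound 2 to compound 3, therefore carry no readable size; both ends of each sit at the limit. Compound 3 stands where every value in this small set stands: the limit of > 20000 nM in this assay, at which 3 of the 3 values shown sit.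

Compound 4 `CNc1ncnc2c1c(-c1cc3ccccc3o1)cn2[C@@H]1O[C@H](CO)[C@@H](O)[C@H]1O` differs from compound 3 by 1-benzofuran-2-yl in place of phenyl on an aromatic carbon. Among the measured compounds shown here, no measured step resembles this exchange, and the two steps that exist are unreadable, so they give no direction for this assay. What the set does show is that iodo, phenyl, methoxy and methylamino at the places varied all leave the value at the limit. The expectation for compound 4 is therefore that it stays at or near the limit, with a modest chance of a readable number. Compound 4 is expected to give 20000 nM in this assay, within 5000 nM to 60000 nM. The estimated step is a number no higher from compound 3 to compound 4 (the limit leaves the size open).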

Compound 4, half-maximal inhibitory concentration: > 20000 nM
Compound 4: a limit, no number; the forecaster's own chance of this, stated with the estimate: 70%; the middle value sits exactly at the limit.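

In this assay compound 4 gives > 20000 nM, which is a limit and not a number. Compound 3 also gives only a limit, so the step between compound 3 and compound 4 cannot be read. The compounds shown leave open whether any group at the places varied gives a readable value in this assay.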